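The source may report more compounds than this note shows. Statements on the series, on what has been measured and on what is new or still open speak of the compounds shown alone.

Measured so far:
compound 1 `CCOC(=O)N1CCC(N2CCC[C@@H](NC(=O)c3ccccc3Cl)C2)CC1` — > 10000 nM
compound 2 `CCOC(=O)N1CCC(NCCNC(=O)c2ccccc2C)CC1` — > 30000 nM

In a functional assay on CHO cells for agonist activity at muscarinic acetylcholine receptor M5 (Rattus norvegicus) (a higher number here means that more compound is needed for the effect, a lower number that less compound is needed), compound 1 gives only (the limit of > 10000 nM in this assay, at which 1 of the 2 values shown sits); this is a limit of the assay, not a number. Compound 2 likewise gives only (the limit of > 30000 nM in this assay, at which 1 of the 2 values shown sits), again a limit. Within the data shown here, no measured step connects the two. Compound 3 `CCOC(=O)N1CCC(N2CCC[C@@H](NC(=O)c3cccs3)C2)CC1` differs from compound 1 by thiophen-2-yl in place of 2-chlorophenyl on a carbonyl carbon. With both known values sitting at limits, no direction can be read from the series; the expectation is no change beyond the scatter, so the step that the limit leaves unreadable from compound 1 to compound 3 is estimated as flat. Compound 3 is expected to show 15000 nM, within 3000 nM to 60000 nM.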

Compound 3, half-maximal effective concentration: > 10000 nM
Compound 3 ended at the assay's limit; the forecaster's own chance of this, stated with the estimate: 75%; the middle value does not contradict the limit.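

Compound 1 gives > 10000 nM, a limit, not a number. Among these compounds, compound 3 gives > 10000 nM, also a limit, so no step between compound 1 and compound 3 can be read. The compounds shown leave open whether thiophen-2-yl and 2-chlorophenyl on a carbonyl carbon differ at all in this read-out.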